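Changing the amide substituent on a shared core

This account rests on a few compounds, and the source may have more. Where it says the series, first, only, none or still open, it means among the compounds named here.

In an ADME assay on microsomes from liver (Mus musculus, strain CD-1) for metabolic stability, read by LC-MS, tested at 2 uM (a lower number here means that the compound disappears faster, a higher number that the compound lasts longer), two compounds have been measured:

compound 1 `Cn1ccc2ccc(-c3cc(Nc4ccccc4S(N)(=O)=O)cc4nccnc34)cc21` gives 0.5 h
compound 2 `CN(C)C(=O)c1ccncc1Nc1cc(-c2ccc3ccn(C)c3c2)c2nccnc2c1` gives 0.35 h

Compound 2 shows the lower of the two numbers, yet its gap to compound 1 lies within the scatter, so the two cannot be ranked. Compound 3 `Cn1ccc2ccc(-c3cc(Nc4cnccc4C(=O)NCC4COCCN4)cc4nccnc34)cc21` differs from compound 2 in one place: ((morpholin-3-yl)methyl)amino in place of dimethylamino on a carbonyl carbon. Within the data shown here, no measured pair shows this change, so the expectation rests on compound 2 alone. The step of a 1.1-fold higher number from compound 2 to compound 3 (0.06 log units; within the scatter) is expected to stay within the scatter, in no clear direction. Compound 3 is therefore estimated at 0.4 h, with a range from 0.15 h to 1 h.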

Compound 3, half-life: > 1 h
Compound 3 ended at the assay's limit (the forecaster's own chance of this, stated with the estimate: 5%); middle value at least 2.5-fold (0.39 log units) from the limit.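

In this assay, ((morpholin-3-yl)methyl)amino in place of dimethylamino on a carbonyl carbon gives an at least 2.8-fold higher number from compound 2 to compound 3 (0.45 log units; beyond the scatter). Among these compounds, this is the first step between measured compounds, and it shows that this position can change how long a compound lasts. Compound 3 sits at a limit of the assay, so the true size of the step stays unknown: the limit of > 1 h in this assay, at which 1 of the 3 values shown sits.

On these data alone, what stays open is which part of the new group matters. A plain methylamino or a (2-methoxyethyl)amino group on the same carbonyl carbon would help separate the ring from the rest of the change.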